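The source may report more compounds than this note shows. Statements on the series, on what has been measured and on what is new or still open speak of the compounds shown alone.

Measured compounds:
- compound 1, `CCC(C)(C)C(=O)O[C@H]1C[C@@H](C)CC2CC[C@H](C)[C@H](CC[C@@H]3C[C@@H](O)CC(=O)O3)C21`: 13 nM
- compound 2, `CCC(C)(C)C(=O)O[C@@H](C[C@@H](C)CO)C1[C@H](O)CC[C@H](C)[C@@H]1CC[C@@H]1C[C@@H](O)CC(=O)O1`: 2800 nM
- compound 3, `CCC(C)(C)C(=O)O[C@H]1C[C@H](C)[C@@H](O)[C@@H]2CC[C@H](C)[C@H](CC[C@@H]3C[C@@H](O)CC(=O)O3)C12`: 48.6 nM

The three compounds were tested in an assay with 3-hydroxy-3-methylglutaryl-coenzyme A reductase (Rattus norvegicus) as the target; on this read-out lower numbers stand for stronger inhibition and higher numbers for weaker inhibition. Compound 1 gives 13 nM in this assay, compound 2 gives 2800 nM, and compound 3 gives 48.6 nM. Compound 3 thus stands second highest of the three numbers; its nearest neighbour is compound 1, whose number is lower by more than the scatter, and its furthest is compound 2, whose number is far higher.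

Compound 4, `CCC(C)(C)C(=O)O[C@H]1C[C@H](C)[C@H](O)[C@@H]2CC[C@H](C)[C@H](CC[C@@H]3C[C@@H](O)CC(=O)O3)C12`, has not yet been measured in this assay. It differs from compound 3 in a single respect: the two compounds have the same atoms and bonds; at least one stereo element is drawn with a configuration in one of them and without one in the other: 1 of 9 stereo elements differ; a stereocentre at a saturated ring carbon is drawn R in compound 3 and S in compound 4; in words, the two compounds have the same atoms and bonds, and a stereocentre at a saturated ring carbon is drawn R in compound 3 and S in compound 4. Going by the values given here, no measured pair in this set shows the effect of such an inversion, so the direction cannot be read from a known step. The author expects the step of a 1.6-fold higher number from compound 3 to compound 4 (0.22 log units; within the scatter) to be modest, possibly a small rise in the number, and estimates for compound 4 a value of 80 nM, ranging from 20 nM to 400 nM.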

Compound 4, half-maximal inhibitory concentration: 289 nM
Compound 4: middle estimate off by 3.6-fold (0.56 log units), on the low side, and the stated range covers the measured number.
By their numbers in this assay, from the lowest: compound 1; then compound 3; then compound 4; then compound 2.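

In this assay the inversion of a single stereocentre at a saturated ring carbon, with atoms and bonds unchanged, gives a 5.9-fold higher number from compound 3 to compound 4 (0.77 log units; beyond the scatter) and so lies beyond the scatter. Going by these compounds alone, the earlier compounds offered no pair that isolated a stereocentre, so this is the first sign that configuration alone at this carbon shifts the number in this assay. The compounds shown give no reason for the size or direction of this step.

On these data alone, whether an amine, a methoxy group or a fluorine on this carbon would give a number closer to that of compound 3 or to that of compound 4 stays open. Equally open, as far as these compounds go, is whether inverting any other stereocentre of the shared core would shift the number to a similar extent.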